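The compounds below may be only part of what the source reports. "The series", "measured", "known", "first", "only" and "open" are said of these compounds alone.

Measured so far in a functional assay on BaF3 cells (Mus musculus) for inhibition, read by CCK-8 assay, with a stated time of 72 h; a lower number here means a stronger inhibitor of growth, a higher number a weaker inhibitor of growth:
- compound 1 `CNc1cc(Oc2ccc(NC(=O)Nc3ccc(C)c(C(F)(F)F)c3)cc2)ncn1`: > 10000 nM
- compound 2 `Cc1ccc(NC(=O)Nc2ccc(Oc3cc(N4CCNC[C@H]4C)ncn3)cc2)cc1C(F)(F)F`: 9670 nM

The result for compound 1 is a limit of this assay, not a number: the limit of > 10000 nM in this assay, at which 1 of the 2 values shown sits. Among the measured compounds shown here, compound 2 gives the only number, so it stands as the sole anchor. For the measured compounds named here, the one measured step, an at least 1.0-fold lower number from compound 1 to compound 2 (0.01 log units; that floor lies within the scatter), starts from a limit and tells little about size.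

Compound 3 `Cc1ccc(NC(=O)Nc2ccc(Oc3cc(/N=C/N(C)C)ncn3)cc2)cc1C(F)(F)F` carries a group of 5 heavy atoms (3 carbon, 2 nitrogen; no ring) in place of a group of 7 heavy atoms (5 carbon, 2 nitrogen; one six-membered non-aromatic ring with 2 hetero atoms), on an aromatic carbon. Going by the values given here, no measured step bears directly on this change, and the only step available is floored at the limit, so no direction beyond the scatter is expected. Compound 3 is estimated at 12000 nM, within 4000 nM to 40000 nM. The expected step is a 1.2-fold higher number from compound 2 to compound 3 (0.09 log units; within the scatter).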

Compound 3, concentration for 50% growth inhibition: 6610 nM
Compound 3: the middle estimate sits 1.8-fold (0.26 log units) above what was measured; the range from low to high includes it.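

Putting the group of 5 heavy atoms (3 carbon, 2 nitrogen; no ring) in place of the 2-methylpiperazin-1-yl group on this aromatic carbon gives a 1.5-fold lower number from compound 2 to compound 3 (0.17 log units; within the scatter) in this assay. At this position, then, the ring, the defined stereocentre and the hydrogen-bond donor can all be lost without a shift beyond the scatter. The size of an at least 1.5-fold lower number from compound 1 to compound 3 (0.17 log units; that floor lies within the scatter) in this assay cannot be read. The result for compound 1 is a limit, not a number: the limit of > 10000 nM in this assay, at which 1 of the 3 values shown sits.

On these data alone, whether a morpholine or an amide on this carbon would move the number beyond the scatter remains open. So does the effect of any change elsewhere on the shared core.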